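Shifting the chain on the aromatic nitrogen of the shared core

The source may report more compounds than this note shows. Statements on the series, on what has been measured and on what is new or still open speak of the compounds shown alone.

Among the measured compounds shown here, compound 2 `CC(=O)Cn1nc(-c2cccnc2)c2ccccc2c1=O` holds the lower of the two numbers measured so far; in an assay on isolated protein (Oryctolagus cuniculus) with Thromboxane-A synthase (Homo sapiens) as the target, tested at 1 uM (on this read-out higher numbers stand for more inhibition at the one concentration tested (going by the name of the read-out) and lower numbers for less inhibition), compound 2 gives 13%, whereas compound 1 `CC(C)n1nc(-c2cccnc2)c2ccccc2c1=O` gives 87%. For the measured compounds named here, the one measured step, a number 74 percentage points lower from compound 1 to compound 2 (beyond the scatter), bears on the next change, since it already shows that what sits on the aromatic nitrogen matters greatly. Compound 3 `CC(C)NC(=O)CCCn1nc(-c2cccnc2)c2ccccc2c1=O` carries 2-(isopropylcarbamoyl)ethyl in place of acetyl on a saturated chain carbon bound to an aromatic nitrogen. Going by the values given here, with only this one step to go by, a moderate rise is expected for compound 3, giving an estimated 40% with a range of 10% to 75%. The step expected is a number 27 percentage points higher from compound 2 to compound 3 (beyond the scatter).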

Compound 3, a percentage reported as inhibition, at one concentration (the size of the read-out at that concentration, not a potency): 89%
Beside the measured number, compound 3's estimate is 49 percentage points below it; measured number above the stated range.
By their numbers in this assay, from the lowest: compound 2; then compounds 1 and 3 (each within the scatter of the next).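

In this assay, replacing acetyl with 2-(isopropylcarbamoyl)ethyl gives a number 76 percentage points higher from compound 2 to compound 3 (beyond the scatter), so a carbonyl-bearing chain at this place need not bring the low number of compound 2. Compound 1 and compound 3 stand within the scatter of each other, so a much larger chain on the shared core still keeps the high level. No measurement available here accounts for the step.

Open, as far as these compounds go, is whether a carboxylic acid or an amine at the chain end would hold this level. Also open, from the compounds shown here alone, is whether a longer chain would do so.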